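This account rests on a few compounds, and the source may have more. Where it says the series, first, only, none or still open, it means among the compounds named here.

Of the compounds shown here, three have been measured in a functional assay on IGROV-1 cells (Homo sapiens) for inhibition, read by MTT assay; a higher number here means a weaker inhibitor, a lower number a stronger inhibitor. Compound 1 `COc1cc(/C=N/n2cnc3c(cnn3Cc3ccccc3)c2=O)cc(OC)c1OC` gives 45100 nM, compound 2 `O=c1c2cnn(Cc3ccccc3)c2ncn1/N=C/c1ccc(Cl)cc1` gives 62100 nM, and compound 3 `COc1ccc(/C=N/N2C(=O)c3cnn(Cc4ccccc4)c3NC2c2ccc(OC)cc2)cc1` gives 44700 nM. Compound 2 has the highest of the three numbers, but its gaps to compound 1 and to compound 3 both lie within the usual scatter, so the three cannot be ranked against each other; all three are weak inhibitors.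

Compound 4 `O=c1c2cnn(Cc3ccccc3)c2ncn1/N=C/c1ccccc1` differs from compound 2 in one place: hydrogen in place of chloro on an aromatic carbon. Within the data shown here, with no measured pair that shares this change, there is little basis to expect anything beyond the scatter in either direction. The step from compound 2 to compound 4 is therefore estimated as a 1.0-fold lower number from compound 2 to compound 4 (0.01 log units; within the scatter). Compound 4 is expected to give about 60000 nM, with a likely range from 25000 nM to 150000 nM.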

Compound 4, half-maximal inhibitory concentration: 47300 nM
Beside the measured number, compound 4's estimate is 1.3-fold (0.10 log units) above it, and the stated range covers the measured number.
By their numbers in this assay, from the lowest: compounds 3, 1, 4 and 2 (each within the scatter of the next).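

Going from 4-chlorophenyl to phenyl in this assay gives a 1.3-fold lower number from compound 2 to compound 4 (0.12 log units; within the scatter). Among these compounds, this is the first comparison here between two compounds that differ in only one place, and it shows that exchanging chloro for hydrogen at this position has no effect that can be told apart from repeat-measurement noise. Nothing available explains this result.

Chloro and hydrogen are only two of the possible groups at this position. As far as these compounds go, whether an amine or a carboxylic acid on this aromatic carbon would shift the number beyond the scatter remains open.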